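Prenyl ether to methylcyclopentyl ether in the melanin-concentrating hormone series

A few compounds are considered here, and "the series" means these few. Any claim that something is new, unique, unknown or untested is made for them only; others in the source may bear on it.

Measured compounds:
Compound 1, `Nc1ccc2cccc(OC3CCCC3)c2n1`: > 2000 nM
Compound 2, `CC(C)=CCOc1cccc2ccc(N)nc12`: > 2000 nM

In an assay on cells with melanin-concentrating hormone receptor 1 (Homo sapiens) as the target, read by radioligand binding (on this read-out higher numbers stand for weaker inhibition and lower numbers for stronger inhibition), compound 1 gives only a limit, > 2000 nM. Compound 2 likewise gives only a limit in this assay, > 2000 nM. The step that the two limits leave unreadable from compound 1 to compound 2 is therefore unreadable, and compound 2 stands at the limit of > 2000 nM in this assay, at which 2 of the 2 values shown sit. Compound 3, `CC1CCC(Oc2cccc3ccc(N)nc23)C1`, differs from compound 2 by 3-methylcyclopentyl in place of 3-methylbut-2-en-1-yl on an oxygen on an aromatic ring. For the measured compounds named here, the only measured step that bears on this change, a step that the two limits leave unreadable from compound 1 to compound 2, gives no size, so no step beyond the scatter can be expected in this assay. Compound 3 is expected at 3000 nM (range 1500 nM to 10000 nM), most likely again as a limit. The expected step is a step that the limit leaves unreadable from compound 2 to compound 3.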

Compound 3, half-maximal inhibitory concentration: 823 nM
For compound 3 the middle estimate is 3.6-fold (0.56 log units) above the measured one; measured number outside the range, below it.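

Compound 3 is the only one of the three with a measured number rather than a limit in this assay, so this oxygen substituent can affect the read-out. Replacing 3-methylbut-2-en-1-yl with 3-methylcyclopentyl gives an at least 2.4-fold lower number from compound 2 to compound 3 (0.38 log units; beyond the scatter), while adding methyl to the saturated ring carbon of the cyclopentyl ether gives an at least 2.4-fold lower number from compound 1 to compound 3 (0.38 log units; beyond the scatter). The full size of each step remains unknown because each starts from a limit: the limit of > 2000 nM in this assay, at which 2 of the 3 values shown sit.

The compounds shown leave open whether ethyl in place of this methyl would lower the number further. They also do not show how a hydroxyl or an amine on the cyclopentyl ring would affect it.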